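Acyl isothiourea to acyl isoselenourea: nitrothiophene pair

The compounds below may be only part of what the source reports. "The series", "measured", "known", "first", "only" and "open" are said of these compounds alone.

In an ADME assay on MCF-10A cells (Homo sapiens) for cytotoxicity, read by MTT assay, with a stated time of 72 h (a higher number here means a weaker inhibitor of growth, a lower number a stronger inhibitor of growth), compound 3 `CS/C(=N\C(=O)c1csc([N+](=O)[O-])c1)NC(=O)c1csc([N+](=O)[O-])c1` gives 1550 nM, the lowest of the three numbers. Compound 1 `CS/C(=N\C(=O)c1ccco1)NC(=O)c1ccco1` gives 8220 nM in this assay, and compound 2 `C[Se]/C(=N\C(=O)c1cnc2ccccc2c1)NC(=O)c1cnc2ccccc2c1` gives 20300 nM, both gaps beyond the scatter, so compound 3 stands as the strongest growth inhibitor among the measured set. Compound 4 `C[Se]/C(=N\C(=O)c1csc([N+](=O)[O-])c1)NC(=O)c1csc([N+](=O)[O-])c1` is not yet measured. It differs from compound 3 as follows: a group of 2 heavy atoms (1 carbon, 1 selenium; no ring) in place of a group of 2 heavy atoms (1 carbon, 1 sulfur; no ring), on a carbon with a double bond to nitrogen. Within the data shown here, no measured pair shows this exchange on the same core; compound 1 and compound 2 carry different acyl groups as well as different chalcogens, so their values cannot isolate the change. The step from compound 3 to compound 4 is expected to be small, a 1.4-fold higher number from compound 3 to compound 4 (0.15 log units; within the scatter), near or just beyond the scatter, toward a weaker inhibitor. Compound 4 is therefore estimated at 2200 nM, within 800 nM to 6500 nM.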

Compound 4, concentration for 50% growth inhibition: 1950 nM
The estimate for compound 4 lay 1.1-fold (0.05 log units) above the measured number; the measured number falls inside the stated range.
By their numbers in this assay, from the lowest: compounds 3 and 4 (each within the scatter of the next); then compound 1; then compound 2.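

In this assay, exchanging methylsulfanyl for its selenium counterpart, on a carbon with a double bond to nitrogen, gives a 1.3-fold higher number from compound 3 to compound 4 (0.10 log units; within the scatter) on an otherwise unchanged core. Among these compounds, this is the first reading of the exchange with nothing else altered, and at this position the two groups cannot be told apart in this assay. Nothing available accounts for this result. Going by these compounds, whether the exchange stays this small with the acyl groups of compound 1 or compound 2 remains open, as does the effect of an ethyl chain in place of the methyl on sulfur or selenium.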